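This account rests on a few compounds, and the source may have more. Where it says the series, first, only, none or still open, it means among the compounds named here.

Compounds measured in a functional assay on Jurkat cells (Homo sapiens) for antiproliferative activity, read by MTT assay, with a stated time of 72 h; on this read-out higher numbers stand for weaker inhibition and lower numbers for stronger inhibition:
Compound 1, `COc1cc(-n2ncnc2-c2cccc([N+](=O)[O-])c2)cc(OC)c1OC`, gives > 10000 nM.
Compound 2, `COc1cc(-n2ncnc2-c2ccc(C)cc2)cc(OC)c1OC`, gives 300 nM.
Compound 3, `COc1cc(-n2ncnc2-c2ccc(SC)cc2)cc(OC)c1OC`, gives 50 nM.

The value for compound 1 is a limit of this assay and not a number. Among the two numbers, compound 3 has the lowest; the nearest is compound 2, and the step of a 6.0-fold lower number from compound 2 to compound 3 (0.78 log units; beyond the scatter) lies beyond the scatter.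

Compound 4 is `COc1cccc(-c2ncnn2-c2cc(OC)c(OC)c(OC)c2)c1`. It differs from compound 3 by 3-methoxyphenyl in place of 4-(methylsulfanyl)phenyl on an aromatic carbon. Going by the values given here, no measured step shows this same change; the only measured step, a 6.0-fold lower number from compound 2 to compound 3 (0.78 log units; beyond the scatter), exchanged one group on the same ring carbon, whereas here both the group and its ring carbon change, so that step gives only a weak guide. Compound 1, which also carries a group on a ring carbon of the same kind, sits at the limit (the limit of > 10000 nM in this assay, at which 1 of the 3 values shown sits), though its group is a different one. The expected step of a 12-fold higher number from compound 3 to compound 4 (1.08 log units; beyond the scatter) is therefore upward in this assay, beyond the scatter but uncertain in size. Compound 4 is estimated at 600 nM, with a range from 150 nM to 3000 nM.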

Compound 4, half-maximal inhibitory concentration: > 10000 nM
Compound 4: a limit, no number; the forecaster's own chance of this, stated with the estimate: 10%; middle value at least 16-fold (1.22 log units) away from the limit.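

In this assay, going by these compounds alone, this aromatic carbon between two ring nitrogen atoms proves far less forgiving than the earlier compounds showed: 3-methoxyphenyl in place of 4-(methylsulfanyl)phenyl gives an at least 200-fold higher number from compound 3 to compound 4 (2.30 log units; beyond the scatter), and 3-methoxyphenyl in place of 4-methylphenyl gives an at least 33-fold higher number from compound 2 to compound 4 (1.52 log units; beyond the scatter). The group that leaves and the group that enters have the same counts of heavy atoms, hydrogen-bond donors and acceptors, so these counts do not separate compound 3 from compound 4. Compound 4 gives a limit and not a number, as does compound 1, and the step between these two cannot be read: the limit of > 10000 nM in this assay, at which 2 of the 4 values shown sit.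

The compounds shown do not separate the effect of the methoxy group from that of its place on the phenyl ring, since the two change together here. As far as these compounds go, how 4-methoxyphenyl, or a phenyl ring carrying an amine, would fare at this carbon remains open.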